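The compounds below may be only part of what the source reports. "The series", "measured", "known", "first", "only" and "open" are said of these compounds alone.

Two compounds share one core and differ only in the group attached to the carbonyl carbon. Compound 1 `COc1cc(Cl)cc(-c2nn(-c3cccc(NC(=O)Nc4ccc(Cl)c(Cl)c4)c3)cc2-c2ccncc2)c1` carries a (3,4-dichlorophenyl)amino there; in a functional assay on PC-3 cells (Homo sapiens) for inhibition, read by sulforhodamine B assay, with a stated time of 48 h, tested at 10 uM (a lower number here means a stronger effect, a higher number a weaker effect of the compound at the concentration tested), compound 1 gives -5.03%. Compound 2 `COc1cc(Cl)cc(-c2nn(-c3cccc(NC(=O)c4cccc(C(F)(F)F)c4)c3)cc2-c2ccncc2)c1` carries a 3-(trifluoromethyl)phenyl instead; in this assay compound 2 gives 23.1%. Within the data shown here, the step of a number 28.1 percentage points higher from compound 1 to compound 2 (beyond the scatter) is the only measured step, and it leaves compound 2 at the higher of the two numbers, the weaker effect, with compound 1 the nearest and lower.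

Compound 3 `COc1cc(Cl)cc(-c2nn(-c3cccc(NC(=O)c4cc(C(F)(F)F)cc(C(F)(F)F)c4)c3)cc2-c2ccncc2)c1` takes compound 2 one step further: trifluoromethyl in place of hydrogen on an aromatic carbon. Among the measured compounds shown here, no measured step adds a group to the six-membered aromatic ring of carbon only, so the single step of a number 28.1 percentage points higher from compound 1 to compound 2 (beyond the scatter) bears on it only indirectly, showing that a change at this end of the molecule can move the read-out by a modest amount. With no closer guide, the step of a number 3.1 percentage points lower from compound 2 to compound 3 (within the scatter) is expected to stay within the scatter. Compound 3 is therefore estimated at 20%, within a range from 0% to 40%.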

Compound 3, a percentage reported as activity, at one concentration (the size of the read-out at that concentration, not a potency): 35.6%
Compound 3: middle estimate off by 15.6 percentage points, on the low side; the measured number falls inside the stated range.
By their numbers in this assay, from the lowest: compound 1; then compound 2; then compound 3.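

Adding a second trifluoromethyl to the six-membered aromatic ring of carbon only, meta to a large group and meta to the first trifluoromethyl, is the first measured change made on that ring itself, and in this assay it gives a number 12.5 percentage points higher from compound 2 to compound 3 (beyond the scatter). A higher number means a weaker effect at the concentration tested, so this carbon is not a neutral place in this series: a group placed here moves the read-out by a modest amount, and in the direction of less effect. Among these compounds, the earlier step of a number 28.1 percentage points higher from compound 1 to compound 2 (beyond the scatter) showed only that exchanging the whole group on the carbonyl carbon could matter, and nothing available here explains why either step goes the way it does.

With one substituent tested at this carbon, the compounds shown cannot separate an effect of trifluoromethyl itself from that of any added group, so a chlorine atom, a methoxy group or an amine at the same place could behave differently. From the compounds shown here alone, whether a second trifluoromethyl would shift the number in the same way on a compound carrying the (3,4-dichlorophenyl)amino group also stays open.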